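Amide nitrogen variation: from compound 3 to compound 4

The source may report more compounds than this note shows. Statements on the series, on what has been measured and on what is new or still open speak of the compounds shown alone.

Compound 3 `CCCCCCCCNC(=O)/C=C/c1c(/C=C/c2ccc(OC)cc2)cc(OC)cc1OC` gives 4280 nM in a functional assay on MCF7 cells (Homo sapiens) for inhibition, read by MTT assay, with a stated time of 48 h (a lower number here means a stronger inhibitor, a higher number a weaker inhibitor), the second highest of three numbers. Compound 1 `CCC(C)NC(=O)/C=C/c1c(/C=C/c2ccc(OC)cc2)cc(OC)cc1OC` gives 3430 nM and compound 2 `COc1ccc(/C=C/c2cc(OC)cc(OC)c2/C=C/C(=O)N2CCCCC2)cc1` gives 6050 nM; the steps of a 1.2-fold higher number from compound 1 to compound 3 (0.10 log units; within the scatter) and a 1.4-fold lower number from compound 2 to compound 3 (0.15 log units; within the scatter) both lie within the scatter, as does a 1.8-fold higher number from compound 1 to compound 2 (0.25 log units; within the scatter). Compound 4 `COc1ccc(/C=C/c2cc(OC)cc(OC)c2/C=C/C(=O)NC(C)C)cc1` differs from compound 3 by isopropyl in place of octyl on an amide-type nitrogen. The step bearing most directly on this change is a 1.2-fold higher number from compound 1 to compound 3 (0.10 log units; within the scatter), sec-butyl exchanged for octyl on the same amide-type nitrogen, which stayed within the scatter; the exchange of piperidin-1-yl for octylamino on the carbonyl carbon, a 1.4-fold lower number from compound 2 to compound 3 (0.15 log units; within the scatter), likewise stayed within the scatter. No step beyond the scatter is therefore expected for a 1.1-fold lower number from compound 3 to compound 4 (0.04 log units; within the scatter). Compound 4 is estimated at 3900 nM, with an expected range of 1900 nM to 8000 nM.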

Compound 4, half-maximal inhibitory concentration: 2560 nM
The estimate for compound 4 lay 1.5-fold (0.18 log units) above the measured number; the measured number falls inside the stated range.
By their numbers in this assay, from the lowest: compounds 4, 1, 3 and 2 (each within the scatter of the next, the first and the last beyond it).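

On the amide-type nitrogen, isopropyl and octyl are not separated in this assay (a 1.7-fold lower number from compound 3 to compound 4 (0.22 log units; within the scatter)), and isopropyl and sec-butyl are not separated either (a 1.3-fold lower number from compound 1 to compound 4 (0.13 log units; within the scatter)). Among the three groups compared on this nitrogen, neither the eight-carbon chain nor the removal of one methyl from sec-butyl gives a step beyond the scatter. Isopropylamino in place of piperidin-1-yl on the carbonyl carbon gives the only such step, and it is modest (a 2.4-fold lower number from compound 2 to compound 4 (0.37 log units; beyond the scatter)).

On these data alone, whether an amine or a carboxylic acid on the chain at the amide-type nitrogen would give a step beyond the scatter remains open. No available evidence accounts for the modest step.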